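Swapping the Styryl Group for a Methoxypyridyl Ring

The source may report more compounds than this note shows. Statements on the series, on what has been measured and on what is new or still open speak of the compounds shown alone.

Compound 1 `COc1ccc(C(=O)c2cc3c(OC)c(OC)c(OC)cc3[nH]2)cc1F` and compound 2 `COc1cc2[nH]c(C(=O)/C=C/c3ccccc3)cc2c(OC)c1OC` share the same core. In a functional assay on B16 cells (Mus musculus) for cytotoxicity, read by MTT assay, with a stated time of 48 h (on this read-out lower numbers stand for stronger inhibition and higher numbers for weaker inhibition), compound 1 gives 16000 nM, and in this assay compound 2 gives 16000 nM, so compound 2 stands level with compound 1 within the scatter. Compound 3 `COc1ccc(C(=O)c2cc3c(OC)c(OC)c(OC)cc3[nH]2)cn1` differs from compound 2 by 6-methoxypyridin-3-yl in place of 2-phenylethenyl on a carbonyl carbon. Within the data shown here, no step between two measured compounds is available to guide this change, so no step beyond the scatter is expected in this assay in either direction. Compound 3 is therefore estimated at 16000 nM, with a range from 5000 nM to 50000 nM, which means an expected step of no change at the digits printed from compound 2 to compound 3 (within the scatter).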

Compound 3, half-maximal inhibitory concentration: > 50000 nM
Compound 3: only a limit was reported; the forecaster's own chance of this, stated with the estimate: 15%; middle value at least 3.1-fold (0.49 log units) away from the limit.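

On the carbonyl carbon, 6-methoxypyridin-3-yl in place of 2-phenylethenyl gives an at least 3.1-fold higher number from compound 2 to compound 3 (0.49 log units; beyond the scatter) in this assay, so the group at this position can matter to the read-out. Compound 1 and compound 2 carry different groups here yet stand level, so they alone gave no sign of this. The step has no upper bound, since compound 3 is recorded only as a limit of the assay: the limit of > 50000 nM in this assay, at which 1 of the 3 values shown sits.

The compounds shown leave open whether the ring nitrogen or the methoxy group of the entering ring goes with the step. They also leave open how an amine or a longer chain on this carbonyl carbon would read in this assay.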